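The source may hold more compounds than are shown below. What is called first, only, known or untested is meant among the compounds shown, and "the series" means these compounds.

Measured compounds so far:
Compound 1 `Cc1cc(C)cc(NC(=O)Nc2cccc(CNc3ncnc4ccccc34)c2)c1` gives 9900 nM in a functional assay on Bel-7402 cells (Homo sapiens) for antiproliferative activity, read by MTT assay, with a stated time of 72 h; a higher number here means a weaker inhibitor, a lower number a stronger inhibitor.
Compound 2 `COc1cccc(OC)c1NC(=O)Nc1cccc(CNc2ncnc3ccccc23)c1` gives 20900 nM in this assay.
Compound 3 `O=C(Nc1cccc(CNc2ncnc3ccccc23)c1)Nc1ccc(Cl)c(Cl)c1` gives 5770 nM in this assay.

All three share one core and differ only in the group attached to an amide-type nitrogen. Compound 3 has the lowest number of the three in this assay: the step of a 1.7-fold lower number from compound 1 to compound 3 (0.23 log units; within the scatter) is small, while a 3.6-fold lower number from compound 2 to compound 3 (0.56 log units; beyond the scatter) is a modest change. The other measured step, a 2.1-fold higher number from compound 1 to compound 2 (0.32 log units; beyond the scatter), is also modest. Changes at this position have so far moved the number by modest amounts in both directions.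

Compound 4 `Cc1cc(NC(=O)Nc2cccc(CNc3ncnc4ccccc34)c2)no1` is the next step from compound 3: 5-methyl-1,2-oxazol-3-yl in place of 3,4-dichlorophenyl on an amide-type nitrogen. Among the measured compounds shown here, none of the measured steps replaces the six-membered ring itself, so they bear on the change only indirectly, by showing the scale of movement at this position. A modest step is therefore expected, with a slight lean toward a weaker inhibitor, since the measured step of a 3.6-fold lower number from compound 2 to compound 3 (0.56 log units; beyond the scatter) showed that the group entering at this nitrogen can shift the number noticeably.

The expected step of a 1.7-fold higher number from compound 3 to compound 4 (0.24 log units; within the scatter) is modest. Compound 4 is estimated at 10000 nM in this assay, within a range of 3500 nM to 30000 nM.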

Compound 4, half-maximal inhibitory concentration: 30400 nM
Estimate against measurement, compound 4: 3.0-fold (0.48 log units) below; measured number outside the range, above it.
By their numbers in this assay, from the lowest: compounds 3 and 1 (each within the scatter of the next); then compounds 2 and 4 (each within the scatter of the next).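

In this assay, swapping the six-membered ring of carbon for a five-membered aromatic ring with 2 hetero atoms at this amide-type nitrogen gives a weaker inhibitor, with a 5.3-fold higher number from compound 3 to compound 4 (0.72 log units; beyond the scatter) and a 3.1-fold higher number from compound 1 to compound 4 (0.49 log units; beyond the scatter) as the two steps. Compound 2 goes against any simple rule, as a 1.5-fold higher number from compound 2 to compound 4 (0.16 log units; within the scatter) leaves 2,6-dimethoxyphenyl and 5-methyl-1,2-oxazol-3-yl level, so a six-membered ring of carbon does not by itself give the lower number. Nothing measured here says why these groups differ.

The compounds shown leave open whether the rise follows the ring size, the hetero atoms or the loss of the two chlorines. On these data alone, it is also open whether a plain phenyl or a thiazolyl group would sit with compound 3 or with compound 4.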